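Ortho-fluoro on the phenyl of the benzyl-substituted spiro compound

The source may report more compounds than this note shows. Statements on the series, on what has been measured and on what is new or still open speak of the compounds shown alone.

Working notes on the series. Compound 1 `Cc1ccc2c(c1)C1(C(=O)N2C)C(C#N)=C(N)Oc2cc3oc(-c4ccccc4)cc(=O)c3c(O)c21` carries a methyl on the amide-type ring nitrogen; in a functional assay on K562 cells (Homo sapiens) for antiproliferative activity, read by MTT assay, with a stated time of 48 h (a higher number here means a weaker inhibitor, a lower number a stronger inhibitor), compound 1 gives 5870 nM. Compound 2 `Cc1ccc2c(c1)C1(C(=O)N2Cc2ccccc2)C(C#N)=C(N)Oc2cc3oc(-c4ccccc4)cc(=O)c3c(O)c21` differs by a phenyl on the saturated chain carbon bound to that nitrogen. For compound 2 this assay reports only a limit, > 50000 nM. That step, an at least 8.5-fold higher number from compound 1 to compound 2 (0.93 log units; beyond the scatter), is the only one here with a readable size. Compound 3 `N#CC1=C(N)Oc2cc3oc(-c4ccccc4)cc(=O)c3c(O)c2C12C(=O)N(Cc1ccccc1)c1ccc(F)cc12` carries fluoro in place of methyl on an aromatic carbon. For compound 3 this assay again reports only a limit, > 50000 nM. The step that the two limits leave unreadable from compound 2 to compound 3 therefore cannot be read, and the two limits leave compound 2 only as a weak member of the series, on the far side of the limit of > 50000 nM in this assay, at which 2 of the 3 values shown sit.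

Compound 4 `Cc1ccc2c(c1)C1(C(=O)N2Cc2ccccc2)C(C#N)=C(N)Oc2cc3oc(-c4ccccc4F)cc(=O)c3c(O)c21` is the candidate: fluoro in place of hydrogen on an aromatic carbon, ortho to a large group; one bond further out this reads phenyl to 2-fluorophenyl. Among the compounds with values here, no measured step probes a fluoro on this phenyl. Within the data shown here, the one readable step, an at least 8.5-fold higher number from compound 1 to compound 2 (0.93 log units; beyond the scatter), concerns a different place, and the step from compound 2 to compound 3 gives no size. Nothing here suggests that a single fluoro would move compound 4 out of the limit region, so the expected step from compound 2 to compound 4, a step that the limit leaves unreadable from compound 2 to compound 4, is essentially none beyond the scatter. Compound 4 is estimated at 60000 nM, in the range 20000 nM to 200000 nM, and most likely the measurement will again return only a limit.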

Compound 4, half-maximal inhibitory concentration: > 50000 nM
Compound 4: a limit, no number; the forecaster's own chance of this, stated with the estimate: 75%; the middle value lies beyond the limit too.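

In this assay compound 4 gives > 50000 nM, a limit and not a number. Compound 2 also stands at a limit, so the step between compound 2 and compound 4 cannot be read: the limit of > 50000 nM in this assay, at which 3 of the 4 values shown sit. The compounds shown leave open whether 2-fluorophenyl in place of phenyl changes the read-out where a number, not a limit, is obtained.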